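Swapping ethynyl for nitro on a cytotoxicity read-out

The source may report more compounds than this note shows. Statements on the series, on what has been measured and on what is new or still open speak of the compounds shown alone.

Of the compounds shown here, three sharing one core have been measured in an ADME assay on RAW264.7 cells (Mus musculus) for cytotoxicity, read by MTT assay, with a stated time of 48 h; on this read-out lower numbers stand for higher toxicity in this test and higher numbers for lower toxicity in this test. Compound 1 `C#CCOc1ccc(-c2noc(NC3CCCCC3)n2)cc1` gives 38.3 ug/mL. Compound 3 `C#Cc1ccc(-c2noc(NC3CCCCC3)n2)cc1` gives 19.8 ug/mL. Compound 2 `C#CCN(c1nc(-c2ccc(C#C)cc2)no1)C1CCCCC1` gives 13.1 ug/mL. Compound 2 therefore sits at the low end of the three numbers: its gap to compound 3 is a 1.5-fold higher number from compound 2 to compound 3 (0.18 log units; within the scatter), while its gap to compound 1 is beyond the scatter.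

The next compound, compound 4 `C#CCN(c1nc(-c2ccc([N+](=O)[O-])cc2)no1)C1CCCCC1`, differs from compound 2 in one place: nitro in place of ethynyl on an aromatic carbon. The same position of the ring was altered once before, when propargyloxy gave way to ethynyl, and that step was a 1.9-fold lower number from compound 1 to compound 3 (0.29 log units; within the scatter). The other recorded step, hydrogen in place of propargyl on a nitrogen on an aromatic ring, was a 1.5-fold higher number from compound 2 to compound 3 (0.18 log units; within the scatter). Going by the values given here, neither step involves a nitro group, so there is no direct precedent for this change. Both recorded changes, however, left this assay largely unmoved, so the step from compound 2 to compound 4 is expected to be small, a 1.1-fold higher number from compound 2 to compound 4 (0.06 log units; within the scatter), with no clear direction. Compound 4 is estimated at 15 ug/mL, in a range from 7 ug/mL to 32 ug/mL.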

Compound 4, half-maximal cytotoxic concentration: 26.7 ug/mL
Estimate against measurement, compound 4: 1.8-fold (0.25 log units) below; the range from low to high includes it.
By their numbers in this assay, from the lowest: compounds 2, 3, 4 and 1 (each within the scatter of the next, the first and the last beyond it).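

In this assay, going by these compounds alone, the exchange of ethynyl for nitro on this aromatic carbon, para to a large group, gives the first step at this position that lies beyond the usual scatter (a 2.0-fold higher number from compound 2 to compound 4 (0.31 log units; beyond the scatter)), whereas the earlier change here stayed within it (a 1.9-fold lower number from compound 1 to compound 3 (0.29 log units; within the scatter)). The higher number stands for lower toxicity in this test, so this position can affect the read-out and the direction here is toward less toxicity, although the step is only modest and rests on a single pair of compounds. The exchange replaces a group with no hydrogen-bond acceptors by one with two, but nothing measured here ties the shift to that difference or to any other feature of the nitro group.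

As far as these compounds go, it remains open whether an amine or a carboxylic acid on the same aromatic carbon would move the number in the same direction, or whether the shift is particular to nitro. It is also open whether nitro would give a step of similar size when the nitrogen carries hydrogen in place of propargyl, since the only nitro compound shown keeps the propargyl group.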